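This account rests on a few compounds, and the source may have more. Where it says the series, first, only, none or still open, it means among the compounds named here.

Compound 1 `COc1ccc(/C=C2\CN(C(=S)SCc3cn(Cc4ccccc4Cl)nn3)C/C(=C\c3ccc(OC)cc3)C2=O)cc1` — in a functional assay on MDA-MB-231 cells (Homo sapiens) for cytotoxicity, read by MTT assay, with a stated time of 24 h (a lower number here means a stronger inhibitor, a higher number a weaker inhibitor), compound 1 gives > 100000 nM, which is a limit of the assay rather than a number.
Compound 2 `Cc1ccc(/C=C2\CN(Cc3cn(Cc4ccccc4F)nn3)C/C(=C\c3ccc(C)cc3)C2=O)cc1` — in this assay compound 2 gives 10000 nM.
Compound 3 `COc1ccc(/C=C2\CN(C(=S)SCc3cn(Cc4ccc(F)cc4)nn3)C/C(=C\c3ccc(OC)cc3)C2=O)cc1` — in this assay compound 3 gives > 100000 nM, again a limit and not a number.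

Compound 3 thus stands at the ceiling of this assay, and it does not stand there alone: the limit of > 100000 nM in this assay, at which 2 of the 3 values shown sit. Compound 2, which differs from the other two in several places at once, is the only one of the three to return a number.

Among the compounds with values here, only one measured step touches a single position, and it runs between the two limit compounds: a step that the two limits leave unreadable from compound 1 to compound 3. Since both of its ends are limits, its size cannot be read, and it offers no measured direction.

Compound 4 `COc1ccc(/C=C2\CN(C(=S)SCc3cn(Cc4cccc(Cl)c4)nn3)C/C(=C\c3ccc(OC)cc3)C2=O)cc1` differs from compound 3 in one place: 3-chlorophenyl in place of 4-fluorophenyl on a saturated chain carbon bound to an aromatic nitrogen. Within the data shown here, the one step that bears on this change, the unreadable one from compound 1 to compound 3, swaps one halogenated phenyl for another on the same carbon without lifting either compound off the limit. Nothing in the three values therefore points to a reading within range, and compound 4 is expected to remain at the limit, so the step of a number no higher from compound 3 to compound 4 (the limit leaves the size open) is estimated to be none beyond the scatter. Compound 4 is accordingly estimated at 100000 nM, with a range from 30000 nM to 300000 nM.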

Compound 4, half-maximal inhibitory concentration: 32000 nM
The estimate for compound 4 lay 3.1-fold (0.49 log units) above the measured number; low and high end bracket the measured number.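

Within the data shown here, this position is not silent after all: on a saturated chain carbon bound to an aromatic nitrogen, 3-chlorophenyl in place of 4-fluorophenyl gives an at least 3.1-fold lower number from compound 3 to compound 4 (0.49 log units; beyond the scatter), the one kind of change here so far with a readable direction. The place of the chlorine on the phenyl ring also matters, for 3-chlorophenyl in place of 2-chlorophenyl gives an at least 3.1-fold lower number from compound 1 to compound 4 (0.49 log units; beyond the scatter), so two compounds carrying the same halogen fall on either side of the limit in this assay. With compound 4 now in range, compound 1 and compound 3 stay at that limit, and the full size of both steps stays unknown: the limit of > 100000 nM in this assay, at which 2 of the 4 values shown sit.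

The compounds shown leave open whether the change at this carbon follows the chlorine or the 3-position of the ring, a question that a 3-fluorophenyl or a 4-chlorophenyl group there could settle. They also leave open how far this series can move into range, as a 3-bromophenyl or 3-methoxyphenyl group on the same carbon, with the rest of compound 4 unchanged, would show.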